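A few compounds are considered here, and "the series" means these few. Any claim that something is new, unique, unknown or untested is made for them only; others in the source may bear on it.

Working notes on the series, all read in an ADME assay on cells (Homo sapiens) for cytotoxicity; on this read-out higher numbers stand for weaker inhibition and lower numbers for stronger inhibition. Compound 1 (`Nc1ccn([C@@H]2S[C@H](CO)C=C2F)c(=O)n1`) gives > 100000 nM, which is a limit of the assay and not a number. Compound 2 (`Nc1ncnc2c1ncn2[C@@H]1S[C@H](CO)C=C1F`) gives > 100000 nM, again a limit. Compound 3 (`O=c1[nH]cnc2c1ncn2[C@@H]1S[C@H](CO)C=C1F`) gives > 100000 nM, also a limit. Compound 3 therefore has no numeric value, and it stands with the other two compounds at the limit of > 100000 nM in this assay, at which 3 of the 3 values shown sit. Going by the values given here, no step between measured compounds is available to size a change.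

Compound 4 (`Nc1nc2c(ncn2[C@@H]2S[C@H](CO)C=C2F)c(=O)[nH]1`) differs from compound 3 by amino in place of hydrogen on an aromatic carbon, between two ring nitrogen atoms. The expected step is a number no higher from compound 3 to compound 4 (the limit leaves the size open), which means no shift beyond the scatter in this assay, and a further limit is the likeliest report. This expectation rests only on compound 3 and the two other compounds sitting at that same limit. For compound 4 the estimated value is 100000 nM, expected within a range from 40000 nM to 150000 nM.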

Compound 4, half-maximal inhibitory concentration: > 100000 nM
Compound 4: only a limit was reported (the forecaster's own chance of this, stated with the estimate: 75%); the middle value lies on the limit itself.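

In this assay compound 4 gives > 100000 nM, a limit and not a number. Going by these compounds alone, with compound 3 also at a limit, no step from compound 3 to compound 4 can be read. The compounds shown leave open where any numeric value in this series would lie: the limit of > 100000 nM in this assay, at which 4 of the 4 values shown sit.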